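This account rests on a few compounds, and the source may have more. Where it says the series, first, only, none or still open, it means among the compounds named here.

Measured so far in a functional assay on HCC1937 cells (Homo sapiens) for antiproliferative activity, read by CCK-8 assay, with a stated time of 72 h; a lower number here means a stronger inhibitor, a higher number a weaker inhibitor:
compound 1 `Cc1ccccc1C(=O)Nc1cccc(-c2oc3cc(-c4ccc(F)cc4)ccc3c(=O)c2O)c1` gives 9900 nM
compound 2 `N#Cc1ccc(C(=O)Nc2cccc(-c3oc4cc(-c5ccc(F)cc5)ccc4c(=O)c3O)c2)cc1` gives 2990 nM

For the measured compounds named here, compound 2 stands at the lower of the two numbers; its only neighbour is compound 1, and the step of a 3.3-fold lower number from compound 1 to compound 2 (0.52 log units; beyond the scatter) lies beyond the scatter. Compound 3 `O=C(Nc1cccc(-c2oc3cc(-c4ccc(F)cc4)ccc3c(=O)c2O)c1)c1ccc([N+](=O)[O-])cc1` is not yet measured. The change is nitro in place of cyano on an aromatic carbon. Going by the values given here, no measured step swaps one para group for another of this kind; the one measured step exchanged the whole aryl ring, so it only loosely bears on this exchange. Compound 3 is therefore expected to stay close to compound 2, with the step of a 1.0-fold higher number from compound 2 to compound 3 (0.00 log units; within the scatter) estimated to fall within the scatter. The estimate for compound 3 in this assay is 3000 nM, range 1200 nM to 8000 nM.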

Compound 3, half-maximal inhibitory concentration: 5640 nM
The estimate for compound 3 lay 1.9-fold (0.27 log units) below the measured number; the range from low to high includes it.
By their numbers in this assay, from the lowest: compounds 2, 3 and 1 (each within the scatter of the next, the first and the last beyond it).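

In this assay, on the aromatic carbon para to a large group, nitrile and nitro are not separated: a 1.9-fold higher number from compound 2 to compound 3 (0.28 log units; within the scatter). For the compounds shown here, the 4-nitrophenyl amide is also not separated from the 2-methylphenyl amide, with a 1.8-fold lower number from compound 1 to compound 3 (0.24 log units; within the scatter), so compound 3 sits within the scatter of both neighbours and the one step beyond the scatter, between compound 1 and compound 2, does not extend to this exchange. No measurement here bears on the cause of these numbers.

Going by these compounds, whether an amine or a carboxylic acid on this same carbon would give numbers in this range remains open.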